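Methyl to hydroxy on the amide-bearing phenyl ring

The source may hold more compounds than are shown below. What is called first, only, known or untested is meant among the compounds shown, and "the series" means these compounds.

Compound 1, `O=C(CSC(=S)N[C@H]1CCOC1=O)Nc1ccc(Cl)cc1`: in a functional assay on SMMC-7721 cells (Homo sapiens) for cytotoxicity, read by MTT assay, with a stated time of 72 h (on this read-out higher numbers stand for weaker inhibition and lower numbers for stronger inhibition), compound 1 gives > 128000 nM, which is a limit of the assay rather than a number.
Compound 2, `O=C(CSC(=S)N[C@H]1CCOC1=O)Nc1cccc(Cl)c1`: in this assay compound 2 gives > 128000 nM, again a limit rather than a number.
Compound 3, `Cc1ccc(NC(=O)CSC(=S)N[C@H]2CCOC2=O)cc1`: in this assay compound 3 gives 32700 nM.

Among the compounds with values here, compound 3 therefore stands as the only compound of the three with a measured number; the other two sit at the limit of > 128000 nM in this assay, at which 2 of the 3 values shown sit. Between the two limits the step that the two limits leave unreadable from compound 1 to compound 2 cannot be read. The readable steps both end at compound 3: an at least 3.9-fold lower number from compound 1 to compound 3 (0.59 log units; beyond the scatter) and an at least 3.9-fold lower number from compound 2 to compound 3 (0.59 log units; beyond the scatter), each of them at least modest and beyond the scatter.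

Compound 4, `O=C(CSC(=S)N[C@H]1CCOC1=O)Nc1ccc(O)cc1`, differs from compound 3 by hydroxy in place of methyl on an aromatic carbon. Within the data shown here, none of the measured steps exchanges a methyl for a hydroxy; the two readable steps concern chloro against methyl, so they offer only indirect guidance, and the limits leave the size of any such effect open. The expectation for compound 4 is therefore a step of about a 1.4-fold higher number from compound 3 to compound 4 (0.14 log units; within the scatter), no more than the scatter in either direction. Compound 4 is thus estimated at 45000 nM, within a range from 12000 nM to 140000 nM, with a fair chance that the assay returns only a limit.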

Compound 4, half-maximal inhibitory concentration: > 128000 nM
Compound 4 ended at the assay's limit; the forecaster's own chance of this, stated with the estimate: 35%; middle value at least 2.8-fold (0.45 log units) away from the limit.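

Within the data shown here, at this position on the ring, para to a large group, hydroxy in place of methyl gives an at least 3.9-fold higher number from compound 3 to compound 4 (0.59 log units; beyond the scatter) in this assay, the first direct reading of this exchange, which the chloro-to-methyl steps could only hint at. Compound 4 gives only a limit of the assay and not a number, so the real size of the step could be larger than the one printed. Chloro in compound 1 and hydroxy in compound 4 both end at that limit, which leaves methyl in compound 3 as the only one of these groups at this position with a measured value, and the series with a single number among limits: the limit of > 128000 nM in this assay, at which 3 of the 4 values shown sit.

As far as these compounds go, compound 1, compound 2 and compound 4 all end at the limit, so the steps among them cannot be read and any order among them stays unknown. From the compounds shown here alone, it also remains open whether a measured value needs methyl itself, or whether a longer chain such as ethyl, a methoxy group or an amine at the same place would give one too.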